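The compounds below may be only part of what the source reports. "The series", "measured", "known", "first", "only" and "open" are said of these compounds alone.

Compound 1 `COc1ncc(-c2ccc3nc(NC(=O)NCCN4CCCCC4)nn3c2)cc1NS(=O)(=O)c1ccc(F)cc1`: 200 nM
Compound 2 `COc1ncc(-c2ccc3nc(NC(=O)NCCN(C)C)nn3c2)cc1NS(=O)(=O)c1ccc(F)cc1`: 560 nM

Both values come from a functional assay on MCF7 cells (Homo sapiens) for cytotoxicity, read by MTT assay, with a stated time of 72 h; on this read-out higher numbers stand for weaker inhibition and lower numbers for stronger inhibition. Compound 2 stands at the higher of the two numbers, 560 nM. Compound 3 `COc1ncc(-c2ccc3nc(NC(=O)NCCN4CCN(C)CC4)nn3c2)cc1NS(=O)(=O)c1ccc(F)cc1` keeps everything else in compound 2 and makes a single change: 4-methylpiperazin-1-yl in place of dimethylamino on a saturated chain carbon, two bonds along the chain from an amide-type nitrogen. The change lies on a saturated chain carbon, two bonds along the chain from an amide-type nitrogen. Going by the values given here, one measured step bears on it: a 2.8-fold higher number from compound 1 to compound 2 (0.45 log units; beyond the scatter). This modest step, beyond the scatter, replaces piperidin-1-yl with dimethylamino at the same place. Among the compounds with values here, compound 3 regains a six-membered non-aromatic ring there, so that step read backwards is the only guide, though no measured compound yet carries 4-methylpiperazin-1-yl. The expected change in this assay is a modest one to a lower number, a 1.9-fold lower number from compound 2 to compound 3 (0.27 log units; within the scatter). For compound 3 the estimated value is 300 nM, with an expected range of 110 nM to 800 nM.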

Compound 3, half-maximal inhibitory concentration: 500 nM
Compound 3: middle estimate off by 1.7-fold (0.22 log units), on the low side; measured number inside the range.
By their numbers in this assay, from the lowest: compound 1; then compounds 3 and 2 (each within the scatter of the next).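

In this assay the entry of 4-methylpiperazin-1-yl gives a 1.1-fold lower number from compound 2 to compound 3 (0.05 log units; within the scatter) and so does not set this group apart from dimethylamino at this place on the chain. Against piperidin-1-yl the same group gives a 2.5-fold higher number from compound 1 to compound 3 (0.40 log units; beyond the scatter) here, which shows that a six-membered non-aromatic ring on this chain carbon does not by itself bring the number down to that of compound 1, the lowest of the three by steps beyond the scatter. Nothing available here explains why compound 1 stands apart from compound 3.

As far as these compounds go, it remains open whether morpholin-4-yl or pyrrolidin-1-yl on the same chain carbon would stand with compound 1 or with compound 2 and compound 3. From the compounds shown here alone, it is equally open whether a longer chain carrying piperidin-1-yl would keep the number of compound 1 in this assay.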